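Nitro in place of methoxy: expected inhibition of compound 4

A few compounds are considered here, and "the series" means these few. Any claim that something is new, unique, unknown or untested is made for them only; others in the source may bear on it.

Measured compounds:
compound 1, `Oc1cccc2cc(-c3ccccc3)ccc12`, gives < 10% in an assay for binding affinity to 17-beta-hydroxysteroid dehydrogenase type 1 (Homo sapiens), with a stated time of 20 min, tested at 1 uM (on this read-out lower numbers stand for less inhibition and higher numbers for more inhibition at the one concentration tested (going by the name of the read-out)), a limit of the assay.
compound 2, `COc1ccc(-c2ccc3c(O)cccc3c2)cc1`, gives 28% in this assay.
compound 3, `Oc1cccc2cc(-c3ccc(F)cc3)ccc12`, gives < 10% in this assay, a limit of the assay.

Going by the values given here, compound 2 is the only member with a real number in this assay; the other two values are limits, the point at which (the limit of < 10% in this assay, at which 2 of the 3 values shown sit). Compound 4, `O=[N+]([O-])c1ccc(-c2ccc3c(O)cccc3c2)cc1`, is not yet measured. Against compound 2 the change is nitro in place of methoxy on an aromatic carbon.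

Among the compounds with values here, two measured steps bear on it. Gaining methoxy gave a number at least 18 percentage points higher from compound 1 to compound 2 (beyond the scatter), and replacing it by fluoro gave a number at least 18 percentage points lower from compound 2 to compound 3 (beyond the scatter). Within the data shown here, in both, methoxy is the group that carries the number, and the one other group tried in this place returns a limit. Nitro is a third group in the same place, with no step of its own among the measured compounds, so the direction rests only on methoxy being the single group with a number. The expected step is a number 10 percentage points lower from compound 2 to compound 4 (within the scatter), pointing down, with a fair chance that only a limit is returned. For compound 4 the estimate in this assay is 18%, expected range 5% to 38%.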

Compound 4, a percentage reported as inhibition, at one concentration (the size of the read-out at that concentration, not a potency): 15%
Beside the measured number, compound 4's estimate is 3 percentage points above it; the measured number falls inside the stated range.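

In this assay, the place para to a large group now holds a second group that returns a number and not a limit, so methoxy no longer stands alone there. The two groups can still be told apart: nitro in place of methoxy gives a number 13 percentage points lower from compound 2 to compound 4 (beyond the scatter). Nitro in place of fluoro gives a number at least 5 percentage points higher from compound 3 to compound 4 (that floor lies within the scatter), and nitro in place of hydrogen gives a number at least 5 percentage points higher from compound 1 to compound 4 (that floor lies within the scatter), so neither comparison sets nitro firmly apart, and both rest on a limit: the limit of < 10% in this assay, at which 2 of the 4 values shown sit.

The compounds shown leave open whether any group at this place rises above methoxy, for instance an amine, a carboxylic acid or a longer chain such as ethoxy. Going by these compounds, all four compounds also carry the same hydroxyl on the shared core, so its part in these readings remains open.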